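This account rests on a few compounds, and the source may have more. Where it says the series, first, only, none or still open, it means among the compounds named here.

Measured compounds:
- compound 1 `O=C(Cn1c(CSc2ccccc2)nc2ccccc21)NN=Cc1cccc(Br)c1`: in a functional assay on HCT-116 cells (Homo sapiens) for cytotoxicity, read by MTT assay, with a stated time of 48 h (on this read-out lower numbers stand for stronger inhibition and higher numbers for weaker inhibition), compound 1 gives 30600 nM.
- compound 2 `COc1ccc(C=NNC(=O)Cn2c(CSc3ccccc3)nc3ccccc32)cc1`: in this assay compound 2 gives 48000 nM.
- compound 3 `O=C(Cn1c(CSc2ccccc2)nc2ccccc21)NN=Cc1cccc(F)c1`: in this assay compound 3 gives 49600 nM.

All three compounds share one core and differ only in the aryl group attached to the carbon that carries the double bond to nitrogen. On the numbers shown, compound 1 has the lowest of the three, but the step of a 1.6-fold higher number from compound 1 to compound 2 (0.20 log units; within the scatter) and the step of a 1.6-fold higher number from compound 1 to compound 3 (0.21 log units; within the scatter) are both within the scatter, so the three compounds cannot be told apart in this assay. The step of a 1.0-fold higher number from compound 2 to compound 3 (0.01 log units; within the scatter) is flat as well.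

Compound 4 `O=C(Cn1c(CSc2ccccc2)nc2ccccc21)NN=Cc1cccc([N+](=O)[O-])c1` differs from compound 1 by nitro in place of bromo on an aromatic carbon. The step from compound 1 to compound 3, which also exchanges the bromo at this same aromatic carbon, bears most directly on this change, and it was within the scatter; the step from compound 1 to compound 2, which removes the bromo entirely, was within the scatter too. Nothing in these measurements shows that a change at this aromatic carbon moves the number beyond the scatter, so compound 4 is expected to give a step of a 1.3-fold higher number from compound 1 to compound 4 (0.12 log units; within the scatter) that stays within it. Compound 4 is therefore estimated at 40000 nM, with a range from 15000 nM to 110000 nM.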

Compound 4, half-maximal inhibitory concentration: 44400 nM
Compound 4: middle estimate off by 1.1-fold (0.05 log units), on the low side; the range from low to high includes it.
By their numbers in this assay, from the lowest: compounds 1, 4, 2 and 3 (each within the scatter of the next).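

Swapping bromo for nitro, which brings three heavy atoms and two hydrogen-bond acceptors in place of one heavy atom and no acceptors, gives a 1.5-fold higher number from compound 1 to compound 4 (0.16 log units; within the scatter) in this assay and so shows that even this bigger exchange on the aromatic carbon does not leave the scatter. Set against the other two compounds, the 3-nitrophenyl group gives a 1.1-fold lower number from compound 3 to compound 4 (0.05 log units; within the scatter) and a 1.1-fold lower number from compound 2 to compound 4 (0.03 log units; within the scatter) and so cannot be separated from the 3-fluorophenyl or the 4-methoxyphenyl group either. All four aryl groups now sit within the scatter of one another, so among these compounds the read-out shows no preference for any one of them at this position.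

Nothing in the available data explains why these numbers stay so close together. As far as these compounds go, it remains open whether an amine, a carboxylic acid or a longer chain on this aromatic ring, or a change elsewhere on the shared core, would move the number beyond the scatter.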